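This account rests on a few compounds, and the source may have more. Where it says the series, first, only, none or still open, it means among the compounds named here.

Measured so far:
compound 1 `Cc1cccc2sc(NC(=O)CCN3CCN(CCCN(C)C)CC3)nc12` — 570 nM
compound 2 `Cc1cccc2sc(NC(=O)CCN3CCN(CCN(C(C)C)C(C)C)CC3)nc12` — 809 nM

Values come from an assay on membranes from brain for displacement of a labelled ligand from Sigma non-opioid intracellular receptor 1 (Cavia porcellus), read by scintillation counting, with a stated time of 120 min; a higher number here means a weaker inhibitor, a lower number a stronger inhibitor. Compound 2 shows the highest of the two numbers; its nearest neighbour is compound 1, and the step of a 1.4-fold higher number from compound 1 to compound 2 (0.15 log units; within the scatter) lies within the scatter, so the two cannot be ordered.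

Compound 3 `Cc1cccc2sc(NC(=O)CCN3CCN(c4ncccn4)CC3)nc12` differs from compound 2 in one place: pyrimidin-2-yl in place of 2-(diisopropylamino)ethyl on an amine nitrogen in a ring. For the measured compounds named here, the only measured step, a 1.4-fold higher number from compound 1 to compound 2 (0.15 log units; within the scatter), concerns the same ring nitrogen, but it swaps one chain-borne group for another and does not involve an aromatic ring. It therefore bears on the present change only loosely, showing that this position tolerates an exchange without a shift beyond the scatter. Going by the values given here, no measured pair covers a ring entering at this nitrogen.

Compound 3 is accordingly expected to stay close to compound 2, with the step of a 1.1-fold higher number from compound 2 to compound 3 (0.05 log units; within the scatter) expected to lie within the scatter but with wide uncertainty. The estimate for compound 3 in this assay is 900 nM, with a range from 250 nM to 3200 nM.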

Compound 3, inhibition constant: 505 nM
Compound 3: middle estimate off by 1.8-fold (0.25 log units), on the high side; the measured number falls inside the stated range.
By their numbers in this assay, from the lowest: compounds 3, 1 and 2 (each within the scatter of the next).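

In this assay the step of a 1.6-fold lower number from compound 2 to compound 3 (0.20 log units; within the scatter) shows that an aromatic ring can stand on the amine nitrogen of the six-membered ring in place of a chain ending in an amine, with no shift beyond the scatter. The step of a 1.1-fold lower number from compound 1 to compound 3 (0.05 log units; within the scatter) reads the same way against 3-(dimethylamino)propyl, so the three groups compared at this nitrogen cannot be ordered, even though the entering pyrimidin-2-yl has one six-membered aromatic ring and the two leaving groups have none. Nothing measured alongside these numbers speaks to why the three fall together.

Open, going by these compounds, is whether a phenyl ring, a benzyl group or a bare hydrogen on this nitrogen would stay within the scatter of these three. Also open, on these data alone, is whether a carboxylic acid at the end of the chain would move the number beyond it.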